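The compounds below may be only part of what the source reports. "The series", "measured", "known", "first", "only" and "open" are said of these compounds alone.

Measured so far:
- compound 1, `CCOC(=O)/C=C/c1ccncc1-c1ccc2[nH]ccc2c1`: > 10000 nM in a functional assay on KB cells (Homo sapiens) for inhibition, read by sulforhodamine B assay, with a stated time of 72 h; a lower number here means a stronger inhibitor of growth, a higher number a weaker inhibitor of growth
- compound 2, `CNC(=O)/C=C/c1ccncc1-c1ccc2c(cnn2C)c1`: > 10000 nM
- compound 3, `CNC(=O)CCc1ccncc1-c1ccc2ccccc2c1`: > 10000 nM

Compound 1 gives only a limit in this assay, and compound 2 gives only a limit as well. Compound 3 likewise sits at a limit, (the limit of > 10000 nM in this assay, at which 3 of the 3 values shown sit), so no number places it relative to the other two; all three rest at the same boundary of what this assay can report, and nothing among them can be called stronger or weaker.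

Compound 4, `O=C(O)/C=C/c1ccncc1-c1ccc2ccccc2c1`, has not been measured. It differs from compound 3 in one place: 2-carboxyethenyl in place of 2-(methylcarbamoyl)ethyl on an aromatic carbon. The 2-carboxyethenyl group enters where the 2-(methylcarbamoyl)ethyl group stood, on the aromatic carbon ortho to the large group and opposite the ring nitrogen.

Among the compounds with values here, with every measured compound at the limit and no measured step to lean on, the expected step that the limit leaves unreadable from compound 3 to compound 4 is none beyond the scatter, since compound 3 itself only shows > 10000 nM. Compound 4 is therefore estimated at 15000 nM, within 5000 nM to 50000 nM, most likely again reported as a limit.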

Compound 4, concentration for 50% growth inhibition: > 10000 nM
Compound 4: a limit, no number; the forecaster's own chance of this, stated with the estimate: 85%; the middle value does not contradict the limit.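

Within the data shown here, compound 3 and compound 4 both sit at a limit in this assay, so no step between them can be read: the limit of > 10000 nM in this assay, at which 4 of the 4 values shown sit. The compounds shown leave open how strongly any of them inhibits growth, and whether 2-carboxyethenyl and 2-(methylcarbamoyl)ethyl differ at all in their effect.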